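Swapping a decyl chain for a trimethoxyphenyl group

The source may report more compounds than this note shows. Statements on the series, on what has been measured and on what is new or still open speak of the compounds shown alone.

Of the compounds shown here, two have so far been tested in a functional assay on HeLa cells (Homo sapiens) for antiproliferative activity, read by sulforhodamine B assay, with a stated time of 48 h; on this read-out higher numbers stand for weaker inhibition of growth and lower numbers for stronger inhibition of growth. Compound 1 `CCCCCCCCn1cc(Cn2c(CC)nc3nc(C(F)(F)F)ccc3c2=O)nn1` gives 1270 nM in this assay. Compound 2 `CCCCCCCCCCn1cc(COc2nc(-c3ccccc3)nc3nc(C(F)(F)F)ccc23)nn1` gives 1040 nM in this assay. Of these two numbers, that of compound 2 is the smaller, but the gap to compound 1 falls within the usual scatter of repeated measurements, so no order between the two can be claimed on this read-out.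

Compound 3 `COc1cc(-n2cc(COc3nc(-c4ccccc4)nc4nc(C(F)(F)F)ccc34)nn2)cc(OC)c1OC` differs from compound 2 in one place: 3,4,5-trimethoxyphenyl in place of decyl on an aromatic nitrogen. Among the compounds with values here, no pair of measured compounds covers an exchange of this kind, so the numbers at hand give no direct guide to how large this step might be or which way it might go. With only the shared core and its behaviour in compounds 1 and 2 to lean on, the step from compound 2 to compound 3 is expected to be a 2.1-fold lower number from compound 2 to compound 3 (0.32 log units; beyond the scatter), a move toward stronger inhibition of growth, but with wide uncertainty. For compound 3 the estimated value in this assay is 500 nM, with a range from 80 nM to 3000 nM.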

Compound 3, concentration for 50% growth inhibition: 890 nM
For compound 3 the middle estimate is 1.8-fold (0.25 log units) below the measured one, and the stated range covers the measured number.
By their numbers in this assay, from the lowest: compounds 3, 2 and 1 (each within the scatter of the next).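

In this assay, replacing the decyl chain with a 3,4,5-trimethoxyphenyl group gives a 1.2-fold lower number from compound 2 to compound 3 (0.07 log units; within the scatter). Within the data shown here, this is the first exchange measured at this position, on an aromatic nitrogen of the five-membered ring, and it shows that two very different groups can give numbers that cannot be told apart: one is an open chain with no ring and 0 hydrogen-bond acceptors, the other has a six-membered aromatic ring and 3 hydrogen-bond acceptors. Nothing available explains why the numbers for these two groups stand so close.

Going by these compounds, it remains open whether other groups at this position, such as an unsubstituted phenyl ring, a short butyl chain or a chain ending in an amine or a carboxylic acid, would move the number beyond the scatter from compound 2. On these data alone, it is also open whether the 3,4,5-trimethoxyphenyl group would give a similar outcome in place of the chain of compound 1, where the shared core is joined differently and carries an ethyl group rather than a phenyl ring.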